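One Ring Stereocentre Away from the Only Measured Number

The compounds below may be only part of what the source reports. "The series", "measured", "known", "first", "only" and "open" are said of these compounds alone.

Within the data shown here, in a functional assay on HL-60 cells (Homo sapiens) for cytotoxicity, read by colorimetric assay and neutral red uptake, with a stated time of 72 h (on this read-out higher numbers stand for weaker inhibition and lower numbers for stronger inhibition), compound 2 (`CO[C@@H](C(=O)N[C@@H]1CC[C@@H](O)CNC1=O)[C@H](O)[C@@H](O)[C@H](O)/C=C/C(C)(C)C`) gives 12100 nM as the only true number so far.

Compound 1 (`CO[C@@H](C(=O)N[C@H]1CC[C@H](O)CNC1=O)[C@H](O)[C@@H](O)[C@H](O)/C=C/C(C)(C)C`) reads > 150000 nM as a limit of the assay and not a number.

Among the measured compounds shown here, the one measured step (an at least 12-fold lower number from compound 1 to compound 2 (1.09 log units; beyond the scatter)) bears directly on what comes next, and the fact that compounds 1 and 2 differ only in the configuration as drawn ties that gap to configuration alone. Compound 3 (`CO[C@@H](C(=O)N[C@@H]1CC[C@H](O)CNC1=O)[C@H](O)[C@@H](O)[C@H](O)/C=C/C(C)(C)C`) departs from compound 2 in a single way (the two compounds have the same atoms and bonds and differ only in configuration as drawn: 1 of 7 stereo elements differ; a stereocentre at a saturated ring carbon is drawn R in compound 2 and S in compound 3) and so keeps every atom and bond. The measured step changed two ring stereocentres, while this change moves only one. A shift in the same direction is therefore expected, toward a higher number and weaker inhibition in this assay, but probably a smaller one. A single step is thin ground, so the range must stay wide. The expected move is a 2.9-fold higher number from compound 2 to compound 3 (0.46 log units; beyond the scatter) on this reasoning, and it should lie beyond the scatter. For compound 3 the estimated value is 35000 nM with an expected range from 9000 nM to 150000 nM in this assay.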

Compound 3, half-maximal inhibitory concentration: > 150000 nM
Compound 3 was reported as a limit; the forecaster's own chance of this, stated with the estimate: 25%; at least 4.2-fold (0.63 log units) between middle value and limit.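

Where the earlier pair changed two ring stereocentres at once, turning over just one of them, a carbon whose groups can sit in two mirror-image arrangements, is already enough in this assay to give an at least 12-fold higher number from compound 2 to compound 3 (1.09 log units; beyond the scatter). This gap belongs to that single stereocentre at a saturated ring carbon, because no atom or bond changes: the fact that compounds 2 and 3 differ only in the configuration as drawn. The value of compound 3, > 150000 nM, is a limit of the assay and not a number.

The step from compound 1 to compound 3 cannot be read, because both compounds sit at the same limit: the limit of > 150000 nM in this assay, at which 2 of the 3 values shown sit. From the compounds shown here alone, all three compounds share the same atoms and bonds, so how the number of compound 2 would respond to an amine or a longer chain on the shared core stays open.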